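Adding a Second Fluoro Group to Compound 2

This account rests on a few compounds, and the source may have more. Where it says the series, first, only, none or still open, it means among the compounds named here.

Measured so far in a functional assay on RAW264.7 cells (Mus musculus) for inhibition; a lower number here means a stronger inhibitor, a higher number a weaker inhibitor:
- compound 1 `CCOC(=O)C1=CCCCC1S(=O)(=O)Nc1ccccc1F` gives 75 nM
- compound 2 `CCOC(=O)C1=CCCCC1S(=O)(=O)Nc1cccc(F)c1` gives 150 nM
- compound 3 `CCOC(=O)C1=CCCCC1S(=O)(=O)Nc1cccc(Cl)c1` gives 66 nM

Compound 2 stands at 150 nM in this series of close relatives. Its closest measured comparison shows a 2.0-fold higher number from compound 1 to compound 2 (0.30 log units; within the scatter), whereas exchanging its fluoro for chloro gives a 2.3-fold lower number from compound 2 to compound 3 (0.36 log units; beyond the scatter). The next compound, compound 4 `CCOC(=O)C1=CCCCC1S(=O)(=O)Nc1cccc(F)c1F`, keeps everything in compound 2 but has fluoro in place of hydrogen on an aromatic carbon, ortho to a fluoro group and ortho to a large group (fluoro in place of hydrogen on an aromatic carbon).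

Within the data shown here, no measured compound carries two halogens, so the evidence is indirect. Compound 1 has a single fluoro at the newly filled place, and its step of a 2.0-fold higher number from compound 1 to compound 2 (0.30 log units; within the scatter) is the most relevant guide. That step is small, so only a modest change seems likely. In this assay the estimated step is a 1.7-fold lower number from compound 2 to compound 4 (0.22 log units; within the scatter), a modest expected move towards a lower number. For compound 4 the expected value is 90 nM, with an estimated range of 40 nM to 200 nM.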

Compound 4, half-maximal inhibitory concentration: 140 nM
The estimate for compound 4 lay 1.6-fold (0.19 log units) below the measured number, and the stated range covers the measured number.
By their numbers in this assay, from the lowest: compounds 3, 1, 4 and 2 (each within the scatter of the next, the first and the last beyond it).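

In this assay, placing a fluoro on this aromatic carbon, ortho to a fluoro group, gives a 1.1-fold lower number from compound 2 to compound 4 (0.03 log units; within the scatter), so this single-atom change at this position shows no readable effect on the number. The same compound can also be reached by placing a fluoro on the other aromatic carbon of compound 1, which gives a 1.9-fold higher number from compound 1 to compound 4 (0.27 log units; within the scatter); thus neither comparison separates the compound carrying two fluoro groups from its relatives carrying one. Nothing available here accounts for this result.

These compounds test only a single small halogen at this position, so a larger group such as methoxy or trifluoromethyl, or an amine, could behave differently. Going by these compounds, whether a chloro here would give the same result also remains open.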